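Shortening the side chain of compound 1

The source may hold more compounds than are shown below. What is called first, only, known or untested is meant among the compounds shown, and "the series" means these compounds.

compound 1 `O=C(/C=C/c1ccc(NC(=O)Nc2ccc(Cl)c(C(F)(F)F)c2)cc1)NC1CCC1` gives 15400 nM in the test below
compound 2 `CC(NC(=O)c1cccc(-c2ccc(NC(=O)Nc3ccc(Cl)c(C(F)(F)F)c3)cc2)c1)c1ccccc1` gives 5170 nM in the same test
compound 3 `CC(NC(=O)/C=C/Oc1ccc(NC(=O)Nc2ccc(Cl)c(C(F)(F)F)c2)cc1)c1ccccc1` gives 20700 nM in the same test

These numbers are half-maximal inhibitory concentrations from a functional assay on A-375 cells (Homo sapiens) for inhibition, read by MTT assay, with a stated time of 120 h (a lower number here means a stronger inhibitor, a higher number a weaker inhibitor), and they share one test. Compound 1 and compound 3 agree within the usual scatter, while compound 2 has a lower number than compound 1, beyond that scatter.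

Compound 4 `CNC(=O)C#Cc1ccc(NC(=O)Nc2ccc(Cl)c(C(F)(F)F)c2)cc1` has not yet been measured. It carries 2-(methylcarbamoyl)ethynyl in place of 2-(cyclobutylcarbamoyl)ethenyl on an aromatic carbon, para to a large group, and the full count of the swap is 2-(methylcarbamoyl)ethynyl in place of 2-(cyclobutylcarbamoyl)ethenyl on an aromatic carbon for comparison.

Within the data shown here, no two measured compounds differ in one place only, so the data do not show what this swap does. The three side chains differ widely, yet their numbers stay fairly close. In this assay no change beyond the scatter is expected, and the estimated 1.1-fold lower number from compound 1 to compound 4 (0.04 log units; within the scatter) is small. For compound 4 the estimated value is 14000 nM with an expected range from 5000 nM to 40000 nM in this test.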

Compound 4, half-maximal inhibitory concentration: > 50000 nM
Compound 4: a limit, no number; the forecaster's own chance of this, stated with the estimate: 15%; middle value at least 3.5-fold (0.55 log units) from the limit.
By their numbers in this assay, from the lowest: compound 2; then compounds 1 and 3 (each within the scatter of the next). At a limit, above all of these: compound 4.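

In this assay, the group on this aromatic carbon clearly matters: putting 2-(methylcarbamoyl)ethynyl in place of 2-(cyclobutylcarbamoyl)ethenyl gives an at least 3.2-fold higher number from compound 1 to compound 4 (0.51 log units; beyond the scatter). The result for compound 4 is a limit of the assay, not a number: the limit of > 50000 nM in this assay, at which 1 of the 4 values shown sits. Among these compounds, this is the first pair here that differs in one place only, so it gives the first direct reading at this position: this shorter, ring-free side chain weakens inhibition, by an amount the limit leaves unknown.

The swap changes two things at once, the double bond to a triple bond and the cyclobutyl ring to a methyl, and the compounds shown cannot separate these two parts. Going by these compounds, how the methyl amide on a double bond, the cyclobutyl amide on a triple bond, or a chain ending in an amine would read remains open.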